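Changing the Group on a Ring Nitrogen

The source may report more compounds than this note shows. Statements on the series, on what has been measured and on what is new or still open speak of the compounds shown alone.

Compound 1 `Nc1ccccc1NC(=O)c1ccc(CSC(=S)N2CCN(c3ccccc3)CC2)cc1` was tested in a functional assay on A-375 cells (Homo sapiens) for antiproliferative activity, read by CCK-8 assay, with a stated time of 72 h, tested at 8 uM (a lower number here means a weaker effect, a higher number a stronger effect of the compound at the concentration tested), where compound 1 gives 88.6%. Compound 2 `Nc1ccccc1NC(=O)c1ccc(CSC(=S)N2CCCc3ccccc32)cc1` gives 81.5% in this assay. Compound 1 stands highest of the two numbers, with compound 2 nearest, but the gap lies within the scatter, so the two cannot be ordered. Compound 3 `Nc1ccccc1NC(=O)c1ccc(CSC(=S)N2CCN(Cc3ccncc3)CC2)cc1` has not yet been measured. It differs from compound 1 by (pyridin-4-yl)methyl in place of phenyl on an amine nitrogen in a ring. Going by the values given here, no step between measured compounds covers such a change, and both measured values sit high. The step of a number 6.6 percentage points lower from compound 1 to compound 3 (within the scatter) is therefore expected to be small, not beyond the scatter. Compound 3 is estimated at 82%, within a range from 60% to 95%.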

Compound 3, a percentage reported as inhibition, at one concentration (the size of the read-out at that concentration, not a potency): 89.5%
Beside the measured number, compound 3's estimate is 7.5 percentage points below it; the range from low to high includes it.
By their numbers in this assay, from the lowest: compounds 2, 1 and 3 (each within the scatter of the next).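

In this assay, putting (pyridin-4-yl)methyl in place of phenyl on the amine nitrogen in the ring gives a number 0.9 percentage points higher from compound 1 to compound 3 (within the scatter), so this position takes a group that carries a hydrogen-bond acceptor, which phenyl lacks, without a change beyond the scatter. Since this is a read-out at one concentration, the step says nothing about potency. No evidence on hand bears on why the step is this small. Still open, as far as these compounds go, is how this nitrogen fares with a group lacking an aromatic ring, such as a short alkyl chain, or one bearing a carboxylic acid.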